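A few compounds are considered here, and "the series" means these few. Any claim that something is new, unique, unknown or untested is made for them only; others in the source may bear on it.

In a functional assay on cells (T-cell, Homo sapiens) for inhibition (on this read-out higher numbers stand for weaker inhibition and lower numbers for stronger inhibition), compound 1 `COc1ccc(-c2cnc3nc(N)nc(N4CCN(C(=O)NCc5ccccc5)CC4)c3n2)cc1OC` gives 18 nM, the lowest of the two numbers shown here. Compound 3 `COc1ccc(-c2cnc3nc(N)nc(NC(C)C)c3n2)cc1OC` gives 600 nM in this assay, a higher number that lies beyond the usual scatter. For compound 2 `CCOc1nc(N)nc2ncc(-c3ccc(Cl)c(Cl)c3)nc12` this assay reports only a limit, > 10000 nM, and not a number (the limit of > 10000 nM in this assay, at which 1 of the 3 values shown sits). Compound 4 `COc1ccc(-c2cnc3nc(N)nc(N4CCN(Cc5ccc(C(C)(C)C)cc5)CC4)c3n2)cc1OC` has not yet been measured in this assay. It differs from compound 1 in one place: 4-(tert-butyl)benzyl in place of benzylcarbamoyl on an amine nitrogen in a ring. Within the data shown here, no step between two measured compounds of this kind has been recorded, so the expectation for compound 4 rests on the values of compound 1 and compound 3 alone. The step of a 5.6-fold higher number from compound 1 to compound 4 (0.74 log units; beyond the scatter) is expected to be a moderate move towards weaker inhibition. Compound 4 is therefore estimated at 100 nM, within a range from 20 nM to 600 nM.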

Compound 4, half-maximal inhibitory concentration: 4300 nM
Compound 4: middle estimate off by 43-fold (1.63 log units), on the low side, outside the stated range (above it).
By their numbers in this assay, from the lowest: compound 1; then compound 3; then compound 4. At a limit, above all of these: compound 2.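

In this assay, putting 4-(tert-butyl)benzyl in place of benzylcarbamoyl on the amine nitrogen in the ring gives a 240-fold higher number from compound 1 to compound 4 (2.38 log units; beyond the scatter), the only one-place step shown, so the group at this position strongly affects the read-out. The entering group has no hydrogen-bond donor or acceptor and carries an added tert-butyl, so several features change at once. Nothing measured here explains the loss. On these data alone, whether it follows from losing the carbonyl and amide hydrogen or from gaining tert-butyl remains open. A plain benzyl group on the same nitrogen would help separate these two changes.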